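The source may hold more compounds than are shown below. What is called first, only, known or untested is meant among the compounds shown, and "the series" means these compounds.

Of the compounds shown here, three built on one shared core have so far been tested in an assay on LtK cells with ATP-sensitive inward rectifier potassium channel 11 (Homo sapiens) as the target; on this read-out lower numbers stand for an effect already at smaller amounts and higher numbers for an effect only at larger amounts of compound. Compound 1 `O=C(Nc1c(C(O)(C(F)(F)F)C(F)(F)F)ccc2ccccc12)c1cccc(C(F)(F)F)c1` carries a 3-(trifluoromethyl)phenyl on the carbonyl carbon, and in this assay compound 1 gives 84 nM. Compound 2 `O=C(Nc1c(C(O)(C(F)(F)F)C(F)(F)F)ccc2ccccc12)c1ccc(F)cc1` carries a 4-fluorophenyl in that place, and compound 2 gives 70 nM; the step of a 1.2-fold lower number from compound 1 to compound 2 (0.08 log units; within the scatter) is small. Compound 3 `O=C(Nc1c(C(O)(C(F)(F)F)C(F)(F)F)ccc2ccccc12)c1ccc(OC(F)(F)F)cc1` carries a 4-(trifluoromethoxy)phenyl, and for compound 3 this assay reports only a limit, > 10000 nM. Compound 3 therefore stands at the limit of the assay, (the limit of > 10000 nM in this assay, at which 1 of the 3 values shown sits), not at a number. The steps of an at least 110-fold higher number from compound 1 to compound 3 (2.07 log units; beyond the scatter) and an at least 140-fold higher number from compound 2 to compound 3 (2.15 log units; beyond the scatter) are both large.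

Compound 4 `O=C(Nc1c(C(O)(C(F)(F)F)C(F)(F)F)ccc2ccccc12)c1cc(Cl)cc(Cl)c1` has not yet been measured. It differs from compound 3 in one place: 3,5-dichlorophenyl in place of 4-(trifluoromethoxy)phenyl on a carbonyl carbon. Both large steps into compound 3 bear on this change, since each replaced a smaller substituted phenyl with the 4-(trifluoromethoxy)phenyl and pushed the number beyond the limit. Leaving that group again is expected to reverse most of that rise, so the estimated step of an at least 83-fold lower number from compound 3 to compound 4 (1.92 log units; beyond the scatter) is expected to be large and downward. Compound 4 is expected to land near 120 nM, within a range from 30 nM to 600 nM.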

Compound 4, half-maximal effective concentration: 306 nM
Compound 4: the middle estimate sits 2.6-fold (0.41 log units) below what was measured, and the stated range covers the measured number.
By their numbers in this assay, from the lowest: compounds 2 and 1 (each within the scatter of the next); then compound 4. At a limit, above all of these: compound 3.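

On the carbonyl carbon, the step of an at least 32-fold lower number from compound 3 to compound 4 (1.51 log units; beyond the scatter) in this assay shows that a phenyl carrying two chlorines gives a measurable number, so the loss seen with the 4-(trifluoromethoxy)phenyl is not shared by every substituted phenyl tested here. The steps of a 4.4-fold higher number from compound 2 to compound 4 (0.64 log units; beyond the scatter) and a 3.6-fold higher number from compound 1 to compound 4 (0.56 log units; beyond the scatter) are modest but beyond the scatter, so this position now shows a middle level as well as the close pair of compounds 1 and 2 and the far-off compound 3. The size of the drop to compound 4 is a bound and not an exact figure, since the value of compound 3 is a limit and not a number: the limit of > 10000 nM in this assay, at which 1 of the 4 values shown sits.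

The compounds shown leave open how a phenyl carrying an amine or a carboxylic acid would read at this position. They also leave open whether the loss in compound 3 belongs to the trifluoromethoxy group itself or to where it sits on the ring, a question that 3-(trifluoromethoxy)phenyl in the same place could help to settle.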